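Two chlorines in place of one on the anilino ring

The source may report more compounds than this note shows. Statements on the series, on what has been measured and on what is new or still open speak of the compounds shown alone.

The three measured compounds share one core. Going by the values given here, compound 1 `O=C(CSc1nc(Nc2ccccc2)c2ccccc2n1)Nc1ccccc1Cl` gives 24400 nM in a functional assay on MDA-MB-231 cells (Homo sapiens) for inhibition, read by MTT assay, with a stated time of 72 h (on this read-out lower numbers stand for stronger inhibition and higher numbers for weaker inhibition), and compound 2 `O=C(CSc1nc(Nc2ccccc2)c2ccccc2n1)Nc1cccc(Cl)c1` gives 16500 nM; the step of a 1.5-fold lower number from compound 1 to compound 2 (0.17 log units; within the scatter) is the only one between measured compounds that differ in a single place. Compound 3 `C=CC(=O)Nc1cccc(NC(=O)CSc2nc(Nc3ccccc3Cl)c3ccccc3n2)c1` gives 12700 nM, the lowest of the three numbers shown, yet it sits within the scatter of both compound 2 and compound 1, so no order among the three can be read from these values.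

Compound 4 `C=CC(=O)Nc1cccc(NC(=O)CSc2nc(Nc3ccc(Cl)c(Cl)c3)c3ccccc3n2)c1` has not been measured. It differs from compound 3 by 3,4-dichlorophenyl in place of 2-chlorophenyl on a nitrogen on an aromatic ring. Among the compounds with values here, the one measured step, from compound 1 to compound 2, concerns a chlorophenyl on an amide-type nitrogen and not the nitrogen on an aromatic ring changed here; it does not bear on this change, and it was in any case within the scatter. With nothing pointing either way, the expected step of a 1.1-fold lower number from compound 3 to compound 4 (0.02 log units; within the scatter) is none beyond the scatter. Compound 4 is therefore estimated at 12000 nM, with a range from 5000 nM to 30000 nM.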

Compound 4, half-maximal inhibitory concentration: 17700 nM
The estimate for compound 4 lay 1.5-fold (0.17 log units) below the measured number, and the stated range covers the measured number.
By their numbers in this assay, from the lowest: compounds 3, 2, 4 and 1 (each within the scatter of the next).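

In this assay, going by these compounds alone, the step at this position, a 1.4-fold higher number from compound 3 to compound 4 (0.14 log units; within the scatter), is the first reading of a change on the nitrogen on an aromatic ring, since the earlier step concerned the amide-type nitrogen. It shows that 3,4-dichlorophenyl in place of 2-chlorophenyl, with one more chlorine on the ring, gives a number that cannot be told apart from that of compound 3 in this assay. No measurement bears on why these two compounds read alike.

From the compounds shown here alone, both groups compared here are chlorophenyl rings, so the reach of this position remains unknown. Going by these compounds, whether a pyridyl ring, or a phenyl ring carrying a carboxylic acid or an amine, on this nitrogen would move the number beyond the scatter stays open.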